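A few compounds are considered here, and "the series" means these few. Any claim that something is new, unique, unknown or untested is made for them only; others in the source may bear on it.

In a functional assay for inhibition, with Homo sapiens as the target (on this read-out higher numbers stand for weaker inhibition and lower numbers for stronger inhibition), compound 1 `COc1ccc2sc(C(=O)Nc3nn[nH]n3)c(Oc3ccccc3)c2c1` gives 10100 nM, compound 2 `COc1ccc2sc(C(=O)Nc3nn[nH]n3)c(OCc3ccccc3)c2c1` gives 23400 nM and compound 3 `COc1ccc2c(OC(C)C)c(C(=O)Nc3nn[nH]n3)sc2c1` gives 37000 nM. Compound 3 thus lies within the scatter of compound 2, while its number is higher than that of compound 1, beyond the scatter. Compound 4 `CC(C)Oc1c(C(=O)Nc2nn[nH]n2)sc2ccccc12` differs from compound 3 as follows: hydrogen in place of methoxy on an aromatic carbon. Going by the values given here, the only measured step, a 2.3-fold higher number from compound 1 to compound 2 (0.36 log units; beyond the scatter), is modest and swaps benzyl in place of phenyl on an oxygen on an aromatic ring, so no measurement covers the loss of methoxy, and that step offers only a rough scale. In this assay, the expected change is a 1.1-fold lower number from compound 3 to compound 4 (0.05 log units; within the scatter), which would be no shift beyond the scatter. For compound 4 the estimated value is 33000 nM, with an expected range from 12000 nM to 90000 nM.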

Compound 4, half-maximal inhibitory concentration: > 100000 nM
Compound 4 was reported as a limit; the forecaster's own chance of this, stated with the estimate: 15%; at least 3.0-fold (0.48 log units) between middle value and limit.
By their numbers in this assay, from the lowest: compound 1; then compounds 2 and 3 (each within the scatter of the next). At a limit, above all of these: compound 4.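

In this assay, hydrogen in place of methoxy on an aromatic carbon gives an at least 2.7-fold higher number from compound 3 to compound 4 (0.43 log units; beyond the scatter). Going by these compounds alone, compounds 1, 2 and 3 all carry the methoxy, so this pair is the first to show that the number depends on that group. The number for compound 4 is a limit, so the step has a lower bound but no exact size: the limit of > 100000 nM in this assay, at which 1 of the 4 values shown sits.

On these data alone, whether a hydroxyl, an amine or a chlorine at this position would give a lower number than hydrogen stays open. So does whether losing methoxy has a similar effect with the phenyl group of compound 1 or the benzyl group of compound 2.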